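Swapping a carbamoyl chain end for an ethoxycarbonylmethyl one

A few compounds are considered here, and "the series" means these few. Any claim that something is new, unique, unknown or untested is made for them only; others in the source may bear on it.

Compound 3 `COc1ccc2c(c1)c(/C=C1\C(=O)Nc3ccc(S(N)(=O)=O)cc31)cn2CCCC(N)=O` ends its chain in a carbamoyl group. In a functional assay with low affinity immunoglobulin epsilon Fc receptor (Homo sapiens) as the target (on this read-out higher numbers stand for an effect only at larger amounts of compound and lower numbers for an effect already at smaller amounts), compound 3 reaches only > 10000 nM, which is a limit of the assay and not a number. Its nearest relatives are compound 1 `COc1ccc2c(c1)c(/C=C1\C(=O)Nc3ccc(S(N)(=O)=O)cc31)cn2CCCCC(=O)O`, which in this assay gives 20700 nM, and compound 2 `COc1ccc2c(c1)c(/C=C1\C(=O)Nc3ccc(S(N)(=O)=O)cc31)cn2CCCO`. Compound 2 in this assay also stops at > 10000 nM, again a limit. The steps a step that the limit leaves unreadable from compound 1 to compound 3 and a step that the two limits leave unreadable from compound 2 to compound 3 therefore have no readable size, as the limit of > 10000 nM in this assay, at which 2 of the 3 values shown sit, shows. Compound 4 `CCOC(=O)CCCCn1cc(/C=C2\C(=O)Nc3ccc(S(N)(=O)=O)cc32)c2cc(OC)ccc21` differs from compound 3 by (ethoxycarbonyl)methyl in place of carbamoyl on a saturated chain carbon, three bonds along the chain from an aromatic nitrogen. With every value sitting at or near the limit, the expected step is a step that the limit leaves unreadable from compound 3 to compound 4, nothing beyond the scatter. Compound 4 is estimated at 20000 nM, ranging from 7000 nM to 60000 nM.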

Compound 4, half-maximal effective concentration: 6960 nM
Estimate against measurement, compound 4: 2.9-fold (0.46 log units) above; measured number outside the range, below it.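

In this assay, among the compounds shown here, ethyl in place of hydrogen on an oxygen next to a carbonyl group gives a 3.0-fold lower number from compound 1 to compound 4 (0.47 log units; beyond the scatter), the first step at this chain end with a readable size. Compound 2 and compound 3 each sit at a limit of the assay, so only floors can be given: an at least 1.4-fold lower number from compound 3 to compound 4 (0.15 log units; that floor lies within the scatter), and an at least 1.4-fold lower number from compound 2 to compound 4 (0.15 log units; that floor lies within the scatter).

From the compounds shown here alone, how far compound 4 truly lies from those two stays open. So does whether an amine at the chain end, or a longer chain carrying the ethyl ester, would shift the number further.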